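The source may report more compounds than this note shows. Statements on the series, on what has been measured and on what is new or still open speak of the compounds shown alone.

Of the compounds shown here, two built on a shared core have been measured in an assay for inhibition of Fatty-acid amide hydrolase 1 (Rattus norvegicus); on this read-out lower numbers stand for stronger inhibition and higher numbers for weaker inhibition. Compound 1 `COC(=O)c1ccccc1CCCCCCC(=O)c1ncc(-c2ccccn2)o1` gives 1 nM in this assay. Compound 2 `O=C(O)c1cccc(CCCCCCC(=O)c2ncc(-c3ccccn3)o2)c1` is reported in this assay only as a limit, > 600 nM, so its true value is not known beyond that bound, as noted in the evidence that (the limit of > 600 nM in this assay, at which 1 of the 2 values shown sits). Compound 3 `O=C(CCCCCCc1ccccc1Cl)c1ncc(-c2ccccn2)o1` has not yet been measured in this assay. It differs from compound 2 by 2-chlorophenyl in place of 3-carboxyphenyl on a saturated chain carbon, six bonds along the chain from a carbonyl carbon. Going by the values given here, no measured pair isolates this single change, so the expectation rests on the two values above: compound 1, which carries an ester rather than an acid on the same ring, sits at the strong end of this assay, while compound 2 sits only at the limit. The expected step from compound 2 to compound 3 is an at least 120-fold lower number from compound 2 to compound 3 (2.07 log units; beyond the scatter), a move toward stronger inhibition well beyond the usual scatter. For compound 3 the estimate in this assay is 5 nM, with a likely range from 1 nM to 40 nM.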

Compound 3, inhibition constant: 1.9 nM
Compound 3: middle estimate off by 2.6-fold (0.42 log units), on the high side, within the range that was stated.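

In this assay, placing 2-chlorophenyl instead of 3-carboxyphenyl on the saturated chain carbon, six bonds along the chain from the carbonyl carbon, gives an at least 310-fold lower number from compound 2 to compound 3 (2.49 log units; beyond the scatter), so a ring with no oxygen-bearing group at this place can still give a low number. Compound 2 is known only as a limit: the limit of > 600 nM in this assay, at which 1 of the 3 values shown sits. Chloro in place of methoxycarbonyl on the aromatic carbon gives a 1.9-fold higher number from compound 1 to compound 3 (0.28 log units; within the scatter), so the ester of compound 1 is not required for a low number.

The step from 3-carboxyphenyl to 2-chlorophenyl changes both the group and its place on the ring, so these compounds cannot show which of the two matters. Going by these compounds, whether a plain phenyl or an aminophenyl would also give a low number at this place remains open.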